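Removing one methyl from compound 3: working notes

The compounds below may be only part of what the source reports. "The series", "measured", "known", "first", "only" and "open" are said of these compounds alone.

Measured in a functional assay on OVCAR-3 cells (Homo sapiens); a higher number here means a weaker inhibitor of growth, a lower number a stronger inhibitor of growth:
- compound 1 `Cc1cc(C)c2c(O)cc(-c3ccc(Cl)cc3)nc2n1`: 18200 nM
- compound 2 `COc1ccc(-c2cc(O)c3cccnc3n2)cc1`: 30200 nM
- compound 3 `COc1ccc(-c2cc(O)c3c(C)cc(C)nc3n2)cc1`: 32400 nM

Compound 3 stands within the scatter of both compound 1 and compound 2, so the three measured compounds show no separation in this assay. Compound 4 `COc1ccc(-c2cc(O)c3ccc(C)nc3n2)cc1` follows from compound 3 by hydrogen in place of methyl on an aromatic carbon, opposite the ring nitrogen: hydrogen in place of methyl on an aromatic carbon.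

Going by the values given here, the only measured step, a 1.8-fold higher number from compound 1 to compound 3 (0.25 log units; within the scatter), is methoxy in place of chloro on an aromatic carbon, a different change, and it gives no direct reading on this methyl. The closer evidence is compound 2, which lacks the methyl groups of compound 3. Compound 2 gives 30200 nM, within the scatter of compound 3. Compound 4 keeps the other methyl group, so no shift beyond the scatter is expected.

The expected change is a 1.0-fold lower number from compound 3 to compound 4 (0.02 log units; within the scatter), with no clear direction. For compound 4 the estimated value is 31000 nM, with an expected range of 18000 nM to 52000 nM.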

Compound 4, concentration for 50% growth inhibition: > 100000 nM
Compound 4: a limit, no number; the forecaster's own chance of this, stated with the estimate: 5%; middle value at least 3.2-fold (0.50 log units) away from the limit.
By their numbers in this assay, from the lowest: compounds 1, 2 and 3 (each within the scatter of the next). At a limit, above all of these: compound 4.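

Compound 4 in this assay gives a limit and not a number: the limit of > 100000 nM in this assay, at which 1 of the 4 values shown sits.

Hydrogen in place of methyl at this position, opposite the ring nitrogen, gives an at least 3.0-fold higher number from compound 3 to compound 4 (0.48 log units; beyond the scatter), so this change is not neutral, a separation that the earlier compounds did not show. Methyl in place of hydrogen gives an at least 3.3-fold higher number from compound 2 to compound 4 (0.51 log units; beyond the scatter), the same direction although a methyl enters rather than leaves, so in these compounds the effect of one methyl depends on whether the other is present and does not simply add up.

From the compounds shown here alone, the full size of both steps stays open, as compound 4 has only a limit. Also open, going by these compounds, is whether an ethyl group, an amine or a carboxylic acid on this aromatic carbon would behave like methyl or like hydrogen, and whether the same holds with chloro in place of methoxy, as in compound 1.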